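Replacing the nitrophenyl on the triazole nitrogen

This account rests on a few compounds, and the source may have more. Where it says the series, first, only, none or still open, it means among the compounds named here.

In a functional assay on HepG2 cells (Homo sapiens) for antiproliferative activity, read by MTT assay, with a stated time of 48 h (a higher number here means a weaker inhibitor, a lower number a stronger inhibitor), compound 3 `N#CC1=C(N)Oc2c(N)cc3nc4ccccc4nc3c2C12C(=O)N(Cc1cnnn1-c1ccc([N+](=O)[O-])cc1)c1ccccc12` gives only a limit, > 50000 nM, and no number. It is the single one of the three values that sits at the limit of > 50000 nM in this assay, at which 1 of the 3 values shown sits. The other two compounds were measured as numbers: compound 1 `CCc1ccccc1-n1nncc1CN1C(=O)C2(C(C#N)=C(N)Oc3c(N)cc4nc5ccccc5nc4c32)c2ccccc21` gives 17900 nM, and compound 2 `N#CC1=C(N)Oc2c(N)cc3nc4ccccc4nc3c2C12C(=O)N(Cc1cnnn1-c1cccc(C(F)(F)F)c1)c1ccccc12` gives 15800 nM.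

Compound 4 `CCc1cccc(CC)c1-n1nncc1CN1C(=O)C2(C(C#N)=C(N)Oc3c(N)cc4nc5ccccc5nc4c32)c2ccccc21` differs from compound 3 by one change: 2,6-diethylphenyl in place of 4-nitrophenyl on an aromatic nitrogen. Among the compounds with values here, two measured steps bear on this position. In an at least 2.7-fold higher number from compound 1 to compound 3 (0.44 log units; beyond the scatter) and in an at least 3.1-fold higher number from compound 2 to compound 3 (0.50 log units; beyond the scatter) the move to the 4-nitrophenyl raised the number beyond the scatter both times, whereas a 1.1-fold lower number from compound 1 to compound 2 (0.05 log units; within the scatter) shows that the two other aryl groups gave numbers within the scatter of each other. Compound 4 carries a 2,6-diethylphenyl, which shares its ethyl substitution with the 2-ethylphenyl of compound 1, so the account expects the change to undo the rise seen on going to compound 3 rather than to add anything beyond it.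

The expected step is an at least 2.7-fold lower number from compound 3 to compound 4 (0.44 log units; beyond the scatter), downward, back into the range of compound 1 and compound 2. Compound 4 is accordingly estimated at 18000 nM in this assay, with a range from 8000 nM to 50000 nM.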

Compound 4, half-maximal inhibitory concentration: 16500 nM
The estimate for compound 4 lay 1.1-fold (0.04 log units) above the measured number; low and high end bracket the measured number.
By their numbers in this assay, from the lowest: compounds 2, 4 and 1 (each within the scatter of the next). At a limit, above all of these: compound 3.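

The 2,6-diethylphenyl group restores what the 4-nitrophenyl group lost in this assay, giving an at least 3.0-fold lower number from compound 3 to compound 4 (0.48 log units; beyond the scatter). Within the data shown here, a second ethyl on the aryl ring, the one change not tested by the earlier compounds, gives a 1.1-fold lower number from compound 1 to compound 4 (0.04 log units; within the scatter), and the comparison with the 3-(trifluoromethyl)phenyl group gives a 1.0-fold higher number from compound 2 to compound 4 (0.02 log units; within the scatter). Across the compounds shown, this position on the triazole nitrogen therefore accepts three differently substituted phenyl groups with numbers that stay within the scatter of one another, and compound 3 is the one compound that goes against this pattern, standing as a limit and not a number: the limit of > 50000 nM in this assay, at which 1 of the 4 values shown sits.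

The compounds shown do not separate the nitro group itself from its place on the phenyl ring, since the 4-nitrophenyl group is the only nitro-bearing aryl here and its limit leaves the full size of the step unknown. They also leave open what an amine or a carboxylic acid on that phenyl ring would do, or a longer alkyl chain on the triazole nitrogen in place of the aryl ring.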